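A few compounds are considered here, and "the series" means these few. Any claim that something is new, unique, unknown or untested is made for them only; others in the source may bear on it.

Compound 3 `O=c1c2ccccc2c(-c2cccnc2)nn1CCSc1ncccn1` gives 86% in an assay on isolated protein (Oryctolagus cuniculus) with Thromboxane-A synthase (Homo sapiens) as the target, tested at 1 uM (a lower number here means less inhibition, a higher number more inhibition at the concentration tested (going by the name of the read-out)), the lowest of the three numbers shown, though the step of a number 5 percentage points lower from compound 1 to compound 3 (within the scatter) lies within the scatter. Compound 1 `CCCCn1nc(-c2cccnc2)c2ccccc2c1=O` gives 91%, and compound 2 `O=c1c2ccccc2c(-c2cccnc2)nn1CCSc1nccs1` gives 97%, so that a number 11 percentage points lower from compound 2 to compound 3 (beyond the scatter) is a modest drop. Compound 4 `O=c1c2ccccc2c(-c2cccnc2)nn1CCCCSc1ncccn1` differs from compound 3 in one place: 2-((pyrimidin-2-yl)sulfanyl)ethyl in place of (pyrimidin-2-yl)sulfanyl on a saturated chain carbon, two bonds along the chain from an aromatic nitrogen. Within the data shown here, none of the measured steps makes a change of this kind; they swap the group on the saturated chain carbon, and even there the numbers moved only a little. The step to compound 4 is therefore expected to be a number 1 percentage points lower from compound 3 to compound 4 (within the scatter), nothing beyond the scatter. Compound 4 is estimated at 85%, with a range from 68% to 96%.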

Compound 4, a percentage reported as inhibition, at one concentration (the size of the read-out at that concentration, not a potency): 96%
Compound 4: middle estimate off by 11 percentage points, on the low side; measured number inside the range.
By their numbers in this assay, from the lowest: compounds 3, 1, 4 and 2 (each within the scatter of the next, the first and the last beyond it).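

In this assay, adding 2 carbons to the chain gives a number 10 percentage points higher from compound 3 to compound 4 (within the scatter), so placing (pyrimidin-2-yl)sulfanyl four bonds along the chain from an aromatic nitrogen causes no change beyond the scatter. The other two comparisons, a number 1 percentage points lower from compound 2 to compound 4 (within the scatter) and a number 5 percentage points higher from compound 1 to compound 4 (within the scatter), also stay within the scatter. No measurement here offers an explanation for these results.

Still open, on these data alone, is whether a longer chain would keep this level of inhibition, or an amine or carboxylic acid in place of (pyrimidin-2-yl)sulfanyl. A reading at one concentration also leaves the potency of these compounds unresolved.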